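Aryl exchange on sulfur: compound 2 to compound 4

The source may hold more compounds than are shown below. What is called first, only, known or untested is meant among the compounds shown, and "the series" means these compounds.

In a functional assay on HeLa cells (Homo sapiens) for inhibition, read by CCK-8 assay, with a stated time of 72 h, tested at 8 uM (on this read-out higher numbers stand for more inhibition of growth at the one concentration tested and lower numbers for less inhibition of growth), compound 2 `Nc1ccccc1NC(=O)c1ccc(CSc2cccc(F)c2)cc1` gives 78.4%. Compound 1 `CCc1ccc(SCc2ccc(C(=O)Nc3ccccc3N)cc2)cc1` gives 71%, which lies within the scatter of compound 2. Compound 3 `Nc1ccccc1NC(=O)/C=C/c1ccc(CSc2ccc(F)cc2)cc1` gives 10.4%, far lower than compound 2 and beyond the scatter.

The next structure is compound 4 `Nc1ccccc1NC(=O)c1ccc(CSc2ccc(Br)cc2)cc1`. The change is 4-bromophenyl in place of 3-fluorophenyl on a sulfur, in words 4-bromophenyl in place of 3-fluorophenyl on a sulfur, whose other neighbour is a saturated chain carbon.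

Among the measured compounds shown here, one measured step bears directly on this place: a number 7.4 percentage points higher from compound 1 to compound 2 (within the scatter), with 3-fluorophenyl in place of 4-ethylphenyl on a sulfur. That single exchange stayed within the scatter. Compound 3 differs from compound 2 in more than one place, so its value cannot be assigned to the group on sulfur. For the measured compounds named here, no measured compound carries the 4-bromophenyl group, and one step is thin evidence.

On that basis, no step beyond the scatter is expected in this assay, and any drift is expected to be slightly downward. The estimated a number 6.4 percentage points lower from compound 2 to compound 4 (within the scatter) stays within the scatter. The expected value for compound 4 is 72%, with an estimated range of 55% to 85%.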

Compound 4, percent growth inhibition at one concentration: 38.2%
The estimate for compound 4 lay 33.8 percentage points above the measured number, and the stated range ends above it.
By their numbers in this assay, from the lowest: compound 3; then compound 4; then compounds 1 and 2 (each within the scatter of the next).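

In this assay, the aryl group on sulfur proves to be a place where an exchange can matter: a number 40.2 percentage points lower from compound 2 to compound 4 (beyond the scatter), although 3-fluorophenyl and 4-bromophenyl have the same heavy-atom count and neither carries a hydrogen-bond donor or acceptor. The comparison with compound 1 gives the same picture, a number 32.8 percentage points lower from compound 1 to compound 4 (beyond the scatter), with bromo in place of ethyl on an aromatic carbon, so a substituent at the ring position shared by 4-ethylphenyl and 4-bromophenyl is compatible with either high or much lower growth inhibition at the one concentration tested. The compounds shown offer no measured basis for explaining this difference.

The series does not separate the identity of the bromo group from its ring position, and a 3-bromophenyl or 4-chlorophenyl group on sulfur, with the shared core unchanged, would bear directly on that question. From the compounds shown here alone, it also remains open how this position would respond to a 4-aminophenyl or 4-carboxyphenyl group, or to an aryl ring with a longer chain than ethyl.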